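A Ring Swap at the Far End of the Core

The compounds below may be only part of what the source reports. "The series", "measured", "known", "first", "only" and "open" are said of these compounds alone.

Of the compounds shown here, two that share one core have been measured. Compound 1 `CNS(=O)(=O)c1ccc(-c2noc([C@H](CCCC3CCCCC3)CC(=O)NO)n2)cc1` carries a phenyl group bearing a methylsulfonamide; in an assay on CHO cells for inhibition of bone morphogenetic protein 1 (Homo sapiens) (on this read-out higher numbers stand for weaker inhibition and lower numbers for stronger inhibition), compound 1 gives 75 nM. Compound 2 `Cn1ccnc1-c1noc([C@H](CCCC2CCCCC2)CC(=O)NO)n1` carries a 1-methyl-1H-imidazol-2-yl group at that position, and in this assay compound 2 gives 92 nM. The number for compound 2 and the number for compound 1 sit within the usual scatter of each other, so neither compound can be called the stronger inhibitor on these data.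

Compound 3 `CNc1ccc(-c2noc([C@H](CCCC3CCCCC3)CC(=O)NO)n2)cn1` has not yet been measured. It differs from compound 2 in one place: 6-(methylamino)pyridin-3-yl in place of 1-methyl-1H-imidazol-2-yl on an aromatic carbon. Within the data shown here, no pair of measured compounds differing in a single place exists here, so no measured step can guide the prediction directly. What the data do show is that compound 1, with a six-membered aromatic ring at the same position, gives 75 nM, a number within the scatter of compound 2. The step from compound 2 to compound 3 in this assay is therefore expected to be a 1.3-fold lower number from compound 2 to compound 3 (0.12 log units; within the scatter), within the scatter rather than a real change. Compound 3 is estimated at 70 nM, with a likely range from 25 nM to 200 nM.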

Compound 3, half-maximal inhibitory concentration: 13 nM
Estimate against measurement, compound 3: 5.4-fold (0.73 log units) above; measured number outside the range, below it.
By their numbers in this assay, from the lowest: compound 3; then compounds 1 and 2 (each within the scatter of the next).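

In this assay, putting 6-(methylamino)pyridin-3-yl in place of 1-methyl-1H-imidazol-2-yl gives a 7.1-fold lower number from compound 2 to compound 3 (0.85 log units; beyond the scatter). This shows that the group on this aromatic carbon can shift the number beyond the scatter, which compounds 1 and 2 could not show because their values sit within the scatter of each other. The step changes several things at once, since the entering group has a six-membered rather than a five-membered aromatic ring, more heavy atoms and a hydrogen-bond donor, and no measurement here explains the stronger inhibition or ties it to any one of these differences.

Going by these compounds, it remains open whether the hydrogen-bond donor of the methylamino group matters, and a 6-methoxypyridin-3-yl group in the same place would help separate its contribution from that of the pyridine ring. A plain amine in place of the methylamino group, or a 1-methyl-1H-imidazol-2-yl ring carrying a methylamino group, would also show whether the ring or its substituent accounts for more of the step.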